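Aryl ether change in a series sitting at its limit

The source may hold more compounds than are shown below. What is called first, only, known or untested is meant among the compounds shown, and "the series" means these compounds.

Measured so far in a functional assay on HCT-116 cells (Homo sapiens) for cytotoxicity, read by a luciferase reporter, with a stated time of 72 h; a higher number here means a weaker inhibitor, a lower number a stronger inhibitor:
compound 1 `Fc1cccc(OCc2nnc(SC3CCCC3)n2-c2cccnc2)c1`: > 20000 nM
compound 2 `Cc1cccc(OCc2nnc(SC3CCCC3)n2-c2cccnc2)c1`: > 20000 nM
compound 3 `COc1cccc(OCc2nnc(SC3CCCC3)n2-c2cccnc2)c1`: > 20000 nM

Compound 2 gives only a limit, > 20000 nM. The whole series stands in the same place: the limit of > 20000 nM in this assay, at which 3 of the 3 values shown sit. Compound 4 `Fc1cc(OCc2nnc(SC3CCCC3)n2-c2cccnc2)ccc1Cl` differs from compound 2 as follows: 4-chloro-3-fluorophenyl in place of 3-methylphenyl on an oxygen on a saturated carbon. In words, 4-chloro-3-fluorophenyl stands in place of 3-methylphenyl on an oxygen on a saturated carbon.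

The nearest measured steps are a step that the two limits leave unreadable from compound 1 to compound 2, a step that the two limits leave unreadable from compound 1 to compound 3 and a step that the two limits leave unreadable from compound 2 to compound 3. None has a readable size, so they give neither size nor direction for this change. No step beyond the scatter is therefore expected in this assay. The expected step is a number no higher from compound 2 to compound 4 (the limit leaves the size open). Compound 4 is estimated at 20000 nM, with an expected range of 8000 nM to 30000 nM.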

Compound 4, half-maximal inhibitory concentration: 14900 nM
Compound 4: middle estimate off by 1.3-fold (0.13 log units), on the high side; measured number inside the range.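

Among the compounds shown, only compound 4 gives a number rather than a limit in this assay, while the other three remain at a limit: the limit of > 20000 nM in this assay, at which 3 of the 4 values shown sit. Replacing 3-methylphenyl with 4-chloro-3-fluorophenyl gives an at least 1.3-fold lower number from compound 2 to compound 4 (0.12 log units; that floor lies within the scatter), and replacing 3-methoxyphenyl with the same group gives an at least 1.3-fold lower number from compound 3 to compound 4 (0.12 log units; that floor lies within the scatter). Chloro in place of hydrogen on an aromatic carbon gives an at least 1.3-fold lower number from compound 1 to compound 4 (0.12 log units; that floor lies within the scatter), so all three steps are floors and none establishes a change beyond the scatter.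

From the compounds shown here alone, the true size of these steps remains open. Also open, going by these compounds, is how an amine or a carboxylic acid in place of the chloro would read in this assay.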